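N-methylation of the amide in an alpha-ketooxazole series

This account rests on a few compounds, and the source may have more. Where it says the series, first, only, none or still open, it means among the compounds named here.

Measured so far:
compound 1, `CNC(=O)c1cnc(C(=O)CCc2ccc(COc3ccccc3)cc2)o1`, 3.6 nM
compound 2, `CNC(=O)c1cnc(C(=O)CCc2ccc(Oc3ccccc3)cc2)o1`, 11 nM
compound 3, `CSc1cnc(C(=O)CCc2ccc(-c3ccccc3)cc2)o1`, 3 nM

In an assay for inhibition of Fatty-acid amide hydrolase 1 (Rattus norvegicus) (on this read-out lower numbers stand for stronger inhibition and higher numbers for weaker inhibition), compound 2 gives the highest number of the three: compound 1 sits at 3.6 nM and compound 3 at 3 nM, and both gaps to compound 2 are beyond the scatter. Compound 2 differs from compound 1 only by phenoxy in place of phenoxymethyl on an aromatic carbon, and that step is a 3.1-fold higher number from compound 1 to compound 2 (0.49 log units; beyond the scatter). Compound 3 differs from compound 2 in two places, so its value says nothing on its own about either change.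

Compound 4, `CN(C)C(=O)c1cnc(C(=O)CCc2ccc(Oc3ccccc3)cc2)o1`, is not yet measured. Relative to compound 2 the difference is methyl in place of hydrogen on an amide-type nitrogen. Among the measured compounds shown here, no measured step bears on this change: the only step in hand, from compound 1 to compound 2, concerns the other end of the molecule, and no pair varies the amide nitrogen alone. The methylcarbamoyl group is present on both of the two compounds with the lower numbers, compound 1 and compound 2, while compound 3 carries methylthio instead, which gives no direction either way. The expectation for compound 4 is therefore set wide around compound 2 and is worded as a 2.3-fold higher number from compound 2 to compound 4 (0.36 log units; beyond the scatter). Compound 4 is estimated at 25 nM, with a range from 6 nM to 100 nM.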

Compound 4, inhibition constant: 5.4 nM
The estimate for compound 4 lay 4.6-fold (0.67 log units) above the measured number, outside the stated range (below it).
By their numbers in this assay, from the lowest: compounds 3, 1 and 4 (each within the scatter of the next); then compound 2.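

In this assay the amide nitrogen accepts a second methyl without loss: methyl in place of the amide hydrogen gives a 2.0-fold lower number from compound 2 to compound 4 (0.31 log units; beyond the scatter), so in this pair the amide hydrogen is not needed for a low number. Among the compounds shown here, this is the only step that varies this position, and it was read with the phenoxy group at the far end of the molecule, so it holds for that background alone. No measurement at hand accounts for the direction of this step.

Still open, on these data alone, is whether the same change would give a similar step with phenoxymethyl at the far end, as in compound 1, or with the phenyl group of compound 3, where methylthio stands in place of the methylcarbamoyl group. Also open, as far as these compounds go, is how far this position can be varied, from the primary amide with no methyl at all to an N-ethyl amide, or to a nitrogen closed into a pyrrolidine or morpholine amide.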